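Working notes: sulfamoyl for dimethylamino on the aryl amide

The source may report more compounds than this note shows. Statements on the series, on what has been measured and on what is new or still open speak of the compounds shown alone.

Compound 1 `O=C(O)Cc1ccc(NC(=O)c2cn(Cc3c(F)cccc3F)c3ccc(=O)[nH]c3c2=O)cc1` gives 176 nM in an in vitro assay on Sf21 cells for inhibition of high affinity 3',5'-cyclic-AMP phosphodiesterase 7A (Homo sapiens), read by scintillation proximity assay, with a stated time of 30 min; on this read-out lower numbers stand for stronger inhibition and higher numbers for weaker inhibition.
Compound 2 `CN(C)c1ccc(NC(=O)c2cn(Cc3c(F)cccc3Cl)c3ccc(=O)[nH]c3c2=O)cc1` gives 39 nM in this assay.

Compound 2 holds the lowest of the two numbers; compound 1 stands at a higher value, a gap beyond the usual scatter. The two measured compounds differ in more than one place, so no single change can be read from them. Compound 3 `NS(=O)(=O)c1ccc(NC(=O)c2cn(Cc3c(F)cccc3Cl)c3ccc(=O)[nH]c3c2=O)cc1` has not yet been measured in this assay. It differs from compound 2 by sulfamoyl in place of dimethylamino on an aromatic carbon. Within the data shown here, no measured pair isolates this change, so the direction is open; a modest rise in the number is expected, with a wide range. The expected step is a 2.3-fold higher number from compound 2 to compound 3 (0.36 log units; beyond the scatter). Compound 3 is estimated at 90 nM, with a range from 20 nM to 400 nM.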

Compound 3, half-maximal inhibitory concentration: 20 nM
Compound 3: middle estimate off by 4.5-fold (0.65 log units), on the high side, and the stated range covers the measured number.
By their numbers in this assay, from the lowest: compounds 3 and 2 (each within the scatter of the next); then compound 1.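

Sulfamoyl in place of dimethylamino on an aromatic carbon, para to a large group, gives a 2.0-fold lower number from compound 2 to compound 3 (0.29 log units; within the scatter) in this assay. This first single-place comparison shows that the two groups cannot be separated on this read-out, even though sulfamoyl enters with a hydrogen-bond donor and dimethylamino has none. No available evidence explains this outcome.

From the compounds shown here alone, whether other groups at this place, such as methylsulfonyl, a nitrile or a primary amine, also stay level with compound 2 remains open. Also open, going by these compounds, is whether the same equivalence holds with other benzyl groups on the core.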